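The source may report more compounds than this note shows. Statements on the series, on what has been measured and on what is new or still open speak of the compounds shown alone.

Within the data shown here, in a functional assay on HeLa cells (Homo sapiens) for antiproliferative activity, read by sulforhodamine B assay, with a stated time of 72 h (a higher number here means a weaker inhibitor, a lower number a stronger inhibitor), compound 2 (`COc1cccc(NC(=S)N/N=C/c2ccc3ccccc3n2)c1`) gives 74500 nM, the only numeric value so far. Compound 1 (`COc1ccccc1NC(=S)N/N=C/c1ccc2ccccc2n1`) is reported only as a limit, > 100000 nM. Compound 3 (`S=C(N/N=C/c1ccc2ccccc2n1)Nc1ccc(Cl)cc1`) changes the group on the amide-type nitrogen: 4-chlorophenyl in place of 3-methoxyphenyl on an amide-type nitrogen. Among the measured compounds shown here, the one measured step at this place, an at least 1.3-fold lower number from compound 1 to compound 2 (0.12 log units; that floor lies within the scatter), swaps methoxyphenyl groups and does not test 4-chlorophenyl. On that step, no change beyond the scatter is expected in this assay. For compound 3 the estimated value is 50000 nM, with an expected range of 10000 nM to 120000 nM. The estimate corresponds to an expected 1.5-fold lower number from compound 2 to compound 3 (0.17 log units; within the scatter).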

Compound 3, half-maximal inhibitory concentration: > 100000 nM
Compound 3: no number, only a limit (the forecaster's own chance of this, stated with the estimate: 20%); at least 2.0-fold (0.30 log units) between middle value and limit.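

In this assay, 4-chlorophenyl in place of 3-methoxyphenyl on the amide-type nitrogen gives an at least 1.3-fold higher number from compound 2 to compound 3 (0.12 log units; that floor lies within the scatter), so this change shows no gain in activity. Compound 3 has only a limit, and the step linking it to the other compound with a limit cannot be read. With this result, the limit becomes the most common outcome among the aryl groups at this position: the limit of > 100000 nM in this assay, at which 2 of the 3 values shown sit.

On these data alone, what an unsubstituted phenyl, a benzyl group or a chain ending in an amine on this nitrogen would give in this assay remains open. As far as these compounds go, the effect of changes to the shared core also remains open.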